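A few compounds are considered here, and "the series" means these few. Any claim that something is new, unique, unknown or untested is made for them only; others in the source may bear on it.

Compound 2 `O=S(=O)(NCCNc1nccc(-c2c(-c3cccc(F)c3)nc3sccn23)n1)c1ccc(F)cc1` and compound 1 `O=S(=O)(NCCCNc1nccc(-c2c(-c3cccc(F)c3)nc3sccn23)n1)c1ccc(F)cc1` share the same core and differ only in the length of the chain carrying the sulfonyl group. In a functional assay on A-375 cells (Homo sapiens) for cytotoxicity, read by MTT assay (on this read-out lower numbers stand for stronger inhibition and higher numbers for weaker inhibition), compound 2 gives 9450 nM, and compound 1 gives 14500 nM. The step of a 1.5-fold lower number from compound 1 to compound 2 (0.19 log units; within the scatter) is the only one measured, and it lies within the scatter, so the two numbers are not distinguished from each other. Compound 2 holds the lowest of the two numbers, with compound 1 close to it.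

Compound 3 `O=S(=O)(NCCNc1nccc(-c2c(-c3cccc(F)c3)nc3sccn23)n1)c1ccc(Cl)cc1` is not yet measured. It differs from compound 2 in one place: chloro in place of fluoro on an aromatic carbon. Within the data shown here, no measured step touches this position; the only step available concerns the chain and says nothing about the fluoro of the (4-fluorophenyl)sulfonyl group. With nothing bearing on it, the expected step is a 1.1-fold lower number from compound 2 to compound 3 (0.05 log units; within the scatter), no change beyond the scatter. Compound 3 is therefore estimated at about 8500 nM in this assay, with a range from 3000 nM to 25000 nM.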

Compound 3, half-maximal inhibitory concentration: 18600 nM
Beside the measured number, compound 3's estimate is 2.2-fold (0.34 log units) below it; the measured number falls inside the stated range.
By their numbers in this assay, from the lowest: compounds 2, 1 and 3 (each within the scatter of the next).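

In this assay, chloro in place of fluoro on an aromatic carbon, para to a large group, gives a 2.0-fold higher number from compound 2 to compound 3 (0.29 log units; within the scatter). This tests a position that the earlier chain step did not touch, and on this read-out fluoro and chloro there are not distinguished from each other. The step that changes the halogen and the chain together, a 1.3-fold higher number from compound 1 to compound 3 (0.11 log units; within the scatter), also stays within the scatter, so the three compounds shown are not separated by either kind of change, and nothing available bears on the result beyond these numbers.

From the compounds shown here alone, it remains open whether a group of another kind on this aromatic carbon, such as methoxy, trifluoromethyl or an amine, would move the number beyond the scatter. Going by these compounds, it is also open whether chloro would give the same picture on the chain of compound 1, and whether a chain longer than that one would separate from the others.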